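Amine swaps on the propoxy chain of the aminoquinazoline core

The source may hold more compounds than are shown below. What is called first, only, known or untested is meant among the compounds shown, and "the series" means these compounds.

Compound 1, `CCN(CC)CCCOc1cc2ncnc(Nc3ccc(C#N)cc3)c2cc1OC`: in a functional assay on MCF7 cells (Homo sapiens) for antiproliferative activity, read by MTT assay, with a stated time of 72 h (on this read-out higher numbers stand for weaker inhibition and lower numbers for stronger inhibition), compound 1 gives only a limit, > 100000 nM.
Compound 2, `COc1cc2c(Nc3ccc(C#N)cc3)ncnc2cc1OCCCN1CCCC1`: compound 2 gives 16200 nM.
Compound 3, `CCOC(=O)C1CCN(CCCOc2cc3ncnc(Nc4ccc(C#N)cc4)c3cc2OC)CC1`: compound 3 gives 34900 nM.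

Compound 3 stands highest of the two real numbers in this assay; the nearest is compound 2, with a 2.2-fold higher number from compound 2 to compound 3 (0.33 log units; beyond the scatter). The limit for compound 1 is stated as such: the limit of > 100000 nM in this assay, at which 1 of the 3 values shown sits.

Compound 4, `COc1cc2c(Nc3ccc(C#N)cc3)ncnc2cc1OCCCN1CCc2ccccc2C1`, carries 1,2,3,4-tetrahydroisoquinolin-2-yl in place of 4-(ethoxycarbonyl)piperidin-1-yl on a saturated chain carbon, three bonds along the chain from an oxygen on an aromatic ring. Every measured step concerns the same position: an at least 6.1-fold lower number from compound 1 to compound 2 (0.79 log units; beyond the scatter), an at least 2.8-fold lower number from compound 1 to compound 3 (0.45 log units; beyond the scatter) and a 2.2-fold higher number from compound 2 to compound 3 (0.33 log units; beyond the scatter). Both cyclic amines sit beyond compound 1, and the smaller ring gives the lower number. For compound 4 a modest lower number is expected, a 2.3-fold lower number from compound 3 to compound 4 (0.37 log units; beyond the scatter). Compound 4 is estimated at 15000 nM, with a range from 5000 nM to 50000 nM.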

Compound 4, half-maximal inhibitory concentration: > 100000 nM
Compound 4 was reported as a limit (the forecaster's own chance of this, stated with the estimate: 10%); at least 6.6-fold (0.82 log units) between middle value and limit.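

In this assay, a ring on the amine is not enough at this position: the change to 1,2,3,4-tetrahydroisoquinolin-2-yl gives an at least 2.8-fold higher number from compound 3 to compound 4 (0.45 log units; beyond the scatter) and an at least 6.1-fold higher number from compound 2 to compound 4 (0.79 log units; beyond the scatter). The result for compound 4 is a limit, so the series now has two compounds at that limit, one with a cyclic amine and one with an open-chain amine: the limit of > 100000 nM in this assay, at which 2 of the 4 values shown sit. The step between compound 1 and compound 4 cannot be read, as both are limits.

Going by these compounds, it remains open whether morpholin-4-yl or unsubstituted piperidin-1-yl would track compound 2 or compound 4. On these data alone, the effect of a longer chain carrying pyrrolidin-1-yl is also open.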